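From methyl to propyl on compound 3

A few compounds are considered here, and "the series" means these few. Any claim that something is new, unique, unknown or untested is made for them only; others in the source may bear on it.

Values from a functional assay (Homo sapiens) for inhibition, with a stated time of 72 h (a higher number here means a weaker inhibitor, a lower number a stronger inhibitor), follow
compound 1 `COc1cc(C(=O)c2cccc3[nH]ccc23)cc(OC)c1OC` gives 51.4 nM
compound 2 `COc1cc(C(=O)c2ccc3cc[nH]c3c2)cc(OC)c1OC` gives 452 nM
compound 3 `COc1cc(C(=O)c2ccc3c(ccn3C)c2)cc(OC)c1OC` gives 12.5 nM

Compound 3 holds the lowest number of the three, and its gaps to compound 1 and to compound 2 both lie beyond the usual scatter. Compound 4 `CCCn1ccc2cc(C(=O)c3cc(OC)c(OC)c(OC)c3)ccc21` differs from compound 3 by ethyl in place of hydrogen on a saturated chain carbon bound to an aromatic nitrogen in a change that reads methyl to propyl, with ethyl in place of hydrogen on a saturated chain carbon bound to an aromatic nitrogen. Among the measured compounds shown here, no measured pair shows this change, so its size in this assay is a matter of judgement. With compound 3 already at the low end of the series (12.5 nM), a rise in the number looks more likely than a further drop. The expected move is a moderate one, a 3.2-fold higher number from compound 3 to compound 4 (0.51 log units; beyond the scatter) as estimated, towards a weaker inhibitor, although a step within the scatter remains possible. The estimate for compound 4 is 40 nM (expected range 10 nM to 200 nM).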

Compound 4, half-maximal inhibitory concentration: 2100 nM
Compound 4: middle estimate off by 53-fold (1.72 log units), on the low side; measured number outside the range, above it.
By their numbers in this assay, from the lowest: compound 3; then compound 1; then compound 2; then compound 4.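

In this assay the change from methyl to propyl gives a 170-fold higher number from compound 3 to compound 4 (2.23 log units; beyond the scatter) and shows that this position, on a saturated chain carbon bound to an aromatic nitrogen, does not tolerate every extension of the chain. Adding ethyl at this one place is enough to move the series from its lowest number to its highest, so the good value of compound 3 depends closely on what sits here. No measurement at hand accounts for the size of this step.

The compounds shown leave open whether the loss builds gradually or appears abruptly, which an ethyl group on the same nitrogen would help to settle. They also leave open whether a branched isopropyl group, a longer chain or a chain ending in an amine or a hydroxyl would behave like propyl.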